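Methylphenyl amine series: ear inhibition at one oral dose

This account rests on a few compounds, and the source may have more. Where it says the series, first, only, none or still open, it means among the compounds named here.

Compound 1 `Cc1ccc(/C=C2\CCCC(CN(C)c3ccc(C)cc3)C2=O)cc1` and compound 2 `Cc1ccc(/C=C2\CCCC(CN(C)c3cccc(C)c3)C2=O)cc1` share one core; compound 3 `COc1ccc(C2(O)/C(=C/c3ccc(C)cc3)CCCC2CN(C)c2ccc(C)cc2)cc1` and compound 4 `COc1ccc(C2(O)/C(=C/c3ccc(C)cc3)CCCC2CN(C)c2cccc(C)c2)cc1` share another, and the difference between the two cores is not broken down here. In a functional assay on the whole organism (Ear, strain Kunming) for inhibition, with Mus musculus as the target, with stated times of 1 h and 30 min, at a dose of 200 mg/kg by the oral route (on this read-out higher numbers stand for more inhibition at the one dose given (going by the name of the read-out) and lower numbers for less inhibition), compound 1 gives 27.6%. In this assay compound 2 gives 35.4%. Between these two the change is 3-methylphenyl in place of 4-methylphenyl on an amine nitrogen, and it made a step of a number 7.8 percentage points higher from compound 1 to compound 2 (within the scatter). In this assay compound 3 gives 29.9%; this value and those of compound 1 and compound 2 all lie within the scatter of one another, so no order among the three is drawn.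

Compound 4 has not yet been measured in this assay. It differs from compound 3 by 3-methylphenyl in place of 4-methylphenyl on an amine nitrogen, the same atoms joined differently. This is the same change as that from compound 1 to compound 2, at the same place, an amine nitrogen whose other neighbours are saturated chain carbon and saturated chain carbon; it occurs twice among the compounds shown. Among the measured compounds shown here, because a number 7.8 percentage points higher from compound 1 to compound 2 (within the scatter) stayed within the scatter, a step of similar size, a number 6.1 percentage points higher from compound 3 to compound 4 (within the scatter), is expected here, while the single measured pair on a different core leaves the width of that expectation broad. For compound 4 the expected value in this assay is 36%, estimated to lie between 24% and 48%.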

Compound 4, a percentage reported as inhibition, in the whole organism at one dose (the size of the read-out at that dose, not a potency): 24.5%
Compound 4: middle estimate off by 11.5 percentage points, on the high side, within the range that was stated.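

On the core of compound 3, 3-methylphenyl in place of 4-methylphenyl on an amine nitrogen gives a number 5.4 percentage points lower from compound 3 to compound 4 (within the scatter) in this assay. Set beside the same change on the other core, this step does not separate from the earlier one: the same change on two cores in this assay, a number 7.8 percentage points higher (within the scatter) from compound 1 to compound 2 and a number 5.4 percentage points lower (within the scatter) from compound 3 to compound 4, 13.2 percentage points apart, within the scatter of two such steps The two pairs therefore give no sign that the core alters the outcome of this change, but they do not show that the change carries over unaltered either, as neither step stands clear of the scatter and the differing directions of the two steps carry no weight.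

What the compounds shown leave open is whether any replacement at this place moves the inhibition read-out at the one oral dose beyond the scatter, as all four compounds carry a methylphenyl group on the amine nitrogen. The effect of a carboxylic acid or an amine on that phenyl ring, or of a longer chain in place of the methyl on the same nitrogen, remains an open question on both cores.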